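Removing the Chloro Group on a Second Urea Core

The compounds below may be only part of what the source reports. "The series", "measured", "known", "first", "only" and "open" are said of these compounds alone.

Compound 1 `COc1ccc(Cl)cc1C(C)NC(=O)N(C)S(=O)(=O)c1ccc(Cl)cc1` and compound 2 `COc1ccc(Cl)cc1C(C)NC(=O)N(C)S(=O)(=O)c1ccccc1` share one core; compound 3 `COc1ccc(OC)c(CNC(=O)N(C)S(=O)(=O)c2ccc(Cl)cc2)c1` and compound 4 `COc1ccc(OC)c(CNC(=O)N(C)S(=O)(=O)c2ccccc2)c1` share another, and the difference between the two cores is not broken down here. In a functional assay on thoracic aorta (Rattus norvegicus, strain Wistar), with a stated time of 15 min (a higher number here means that more compound is needed for the effect, a lower number that less compound is needed), compound 1 gives 20000 nM, and compound 2 gives 7200 nM, so that a 2.8-fold lower number from compound 1 to compound 2 (0.44 log units; beyond the scatter). The change behind that step is hydrogen in place of chloro on an aromatic carbon. In this assay compound 3 gives 18200 nM, close to compound 1. Compound 4 carries the same change on its own core: hydrogen in place of chloro on an aromatic carbon. Within the data shown here, since the single measured step is a 2.8-fold lower number from compound 1 to compound 2 (0.44 log units; beyond the scatter), compound 4 is expected to show a step of about that size, a 2.8-fold lower number from compound 3 to compound 4 (0.45 log units; beyond the scatter), though this rests on one precedent only. The estimate for compound 4 in this assay is 6500 nM, with a range from 3000 nM to 15000 nM.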

Compound 4, half-maximal effective concentration: 21300 nM
Beside the measured number, compound 4's estimate is 3.3-fold (0.52 log units) below it, and the stated range ends below it.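

In this assay the change from 4-chlorophenyl to phenyl gives a 1.2-fold higher number from compound 3 to compound 4 (0.07 log units; within the scatter) and so does not repeat the step seen on the other core. The size of the step thus differs between these two cores: the same change on two cores in this assay, a 2.8-fold lower number (0.44 log units; beyond the scatter) from compound 1 to compound 2 and a 1.2-fold higher number (0.07 log units; within the scatter) from compound 3 to compound 4, 3.3-fold (0.51 log units) apart, beyond the scatter of two such steps. Among these compounds, this shows that the step on one core was no reliable guide to the step on the other, but with only two cores it does not show which difference between them is responsible, nor how the change would behave on a third core.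

The compounds shown carry only chloro or hydrogen at this place on the aromatic ring. As far as these compounds go, how a fluoro group, a nitrile or an amine there would read in this assay stays open on either core.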